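The source may hold more compounds than are shown below. What is called first, only, known or untested is meant among the compounds shown, and "the series" means these compounds.

In an ADME assay on the whole organism (strain Sprague-Dawley) for metabolic stability, with Rattus norvegicus as the target, at a dose of 10 mg/kg by the oral route (on this read-out higher numbers stand for a longer-lived compound and lower numbers for a shorter-lived compound), compound 2 `O=C(NOCCO)c1cc2ccoc2c(F)c1Nc1ccc(I)cc1F` gives 1.7 h and compound 1 `O=C(NOC[C@H](O)CO)c1cc2ccoc2c(F)c1Nc1ccc(I)cc1F` gives 3.4 h. These two values lie within the scatter of each other, so compound 2 cannot yet be separated from compound 1. Compound 3 `O=C(NOC(CO)CO)c1cc2ccoc2c(F)c1Nc1ccc(I)cc1F` differs from compound 2 by hydroxymethyl in place of hydrogen on a saturated chain carbon bound to an oxygen and a saturated chain carbon, which turns 2-hydroxyethoxy into 2-hydroxy-1-(hydroxymethyl)ethoxy. Among the measured compounds shown here, one measured step bears on this change: a 2.0-fold lower number from compound 1 to compound 2 (0.30 log units; within the scatter). That step also exchanges hydroxymethyl and hydrogen on a saturated chain carbon, though in the opposite sense and with different surroundings at that carbon. As it stays within the scatter, only a slight lean towards a higher number is expected in this assay, and no step beyond the scatter. The expected step is a 1.5-fold higher number from compound 2 to compound 3 (0.18 log units; within the scatter). The estimated value for compound 3 is 2.6 h, with an expected range of 1.2 h to 5.5 h.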

Compound 3, half-life: 2.5 h
Estimate against measurement, compound 3: 1.0-fold (0.02 log units) above, within the range that was stated.
By their numbers in this assay, from the lowest: compounds 2, 3 and 1 (each within the scatter of the next).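

In this assay, hydroxymethyl in place of hydrogen on a saturated chain carbon bound to an oxygen and a saturated chain carbon gives a 1.5-fold higher number from compound 2 to compound 3 (0.17 log units; within the scatter) and so does not separate 2-hydroxy-1-(hydroxymethyl)ethoxy from 2-hydroxyethoxy. With 2-hydroxy-1-(hydroxymethyl)ethyl in place of 2,3-dihydroxypropyl on an oxygen, the step is a 1.4-fold lower number from compound 1 to compound 3 (0.13 log units; within the scatter) and these two chains cannot be told apart either, so none of the three compounds stands clear of the others at this position. As far as these compounds go, it remains open whether a longer chain, or a chain ending in an amine or a carboxylic acid, would give a step beyond the scatter. The compounds shown also leave open whether the same changes hold on another core. No measured evidence accounts for these numbers.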